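A few compounds are considered here, and "the series" means these few. Any claim that something is new, unique, unknown or untested is made for them only; others in the source may bear on it.

Working notes on the series. The shared core is carried by compound 1 `NCCOc1ccc([C@H]2CC[C@]3(CC2)OOC2(O3)C3CC4CC(C3)CC2C4)cc1`, compound 2 `CC(C)(O)CN1CCC(Oc2ccc([C@H]3CC[C@]4(CC3)OOC3(O4)C4CC5CC(C4)CC3C5)cc2)CC1` and compound 3 `N[C@H]1CC[C@@H](Oc2ccc([C@H]3CC[C@]4(CC3)OOC3(O4)C4CC5CC(C4)CC3C5)cc2)CC1`. In an ADME assay on microsomes from liver (Homo sapiens) for metabolic stability, read by LC-MS, tested at 1 uM (a lower number here means slower removal, a higher number faster removal of the compound), compound 3 gives < 7 mL.min-1.g-1, which is a limit of the assay rather than a number. Compound 1 likewise gives < 7 mL.min-1.g-1, also a limit. Compound 2 gives 18 mL.min-1.g-1, so that an at least 2.5-fold lower number from compound 2 to compound 3 (0.41 log units; beyond the scatter), while a step that the two limits leave unreadable from compound 1 to compound 3, because both sit at the limit of < 7 mL.min-1.g-1 in this assay, at which 2 of the 3 values shown sit. Compound 4 `c1cc([C@H]2CC[C@]3(CC2)OOC2(O3)C3CC4CC(C3)CC2C4)ccc1OCC1CCNCC1` is not yet measured; it differs from compound 3 by (piperidin-4-yl)methyl in place of 4-aminocyclohexyl on an oxygen on an aromatic ring. Compound 3 and compound 1 sit at the limit, compound 2 does not. For compound 4 the expected step is an at least 1.1-fold higher number from compound 3 to compound 4 (0.05 log units; that floor lies within the scatter), small. Compound 4 is therefore expected to give 8 mL.min-1.g-1, between 3.5 mL.min-1.g-1 and 18 mL.min-1.g-1.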

Compound 4, intrinsic clearance in microsomes: < 7 mL.min-1.g-1
Compound 4: only a limit was reported (the forecaster's own chance of this, stated with the estimate: 45%); middle value at least 1.1-fold (0.05 log units) away from the limit.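

In this assay compound 4 gives < 7 mL.min-1.g-1, a limit of the assay. The (piperidin-4-yl)methyl group thus joins 2-aminoethyl and 4-aminocyclohexyl at the limit on this oxygen; the exception is 1-(2-hydroxy-2-methylpropyl)piperidin-4-yl, with an at least 2.5-fold lower number from compound 2 to compound 4 (0.41 log units; beyond the scatter). The steps linking compound 4 with compound 3 and compound 1 cannot be read, as all three sit at one limit: the limit of < 7 mL.min-1.g-1 in this assay, at which 3 of the 4 values shown sit.

On these data alone, the true values of these three compounds stay open. So does the reading for 1-methylpiperidin-4-yl on the same oxygen, which would carry a simple methyl in place of the 2-hydroxy-2-methylpropyl chain.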